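A Methyl on the Saturated Ring: Compound 2 to Compound 4

The source may hold more compounds than are shown below. What is called first, only, known or untested is meant among the compounds shown, and "the series" means these compounds.

Compound 1, `C[C@@H]1CCCN1c1c(C#N)c2c(N)nc(Nc3cn[nH]c3)nc2n1C`: 0.2 nM
Compound 2, `Cn1c(N2CCCC2)c(C#N)c2c(N)ncnc21`: 41 nM
Compound 3, `Cc1cn(C)nc1Nc1cc2c(c(N)n1)c(C#N)c(N1CCC[C@H]1C)n2C`: 63 nM

These three compounds have been measured in an assay on isolated protein for binding affinity to Leucine-rich repeat serine/threonine-protein kinase 2 (Homo sapiens), read by TR-FRET and LanthaScreen, with a stated time of 2 h; a lower number here means a stronger inhibitor, a higher number a weaker inhibitor. Compound 2 has the second highest number of the three; its value lies close to that of compound 3, within the usual scatter, while compound 1 lies far lower, beyond the scatter. Compound 4, `C[C@@H]1CCCN1c1c(C#N)c2c(N)ncnc2n1C`, has not yet been measured. It differs from compound 2 by methyl in place of hydrogen on a saturated ring carbon. Going by the values given here, no measured pair shows this change alone: compound 1 and compound 3 both carry the methylated ring, but each differs from compound 2 in other places too, so their values give no clean step. A modest gain toward a lower number, perhaps just beyond the scatter, is expected; the step of a 3.4-fold lower number from compound 2 to compound 4 (0.53 log units; beyond the scatter) is an estimate. Compound 4 is expected to give about 12 nM, within a range from 2.5 nM to 50 nM.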

Compound 4, inhibition constant: 0.4 nM
Compound 4: middle estimate off by 30-fold (1.48 log units), on the high side; measured number below the stated range.
By their numbers in this assay, from the lowest: compounds 1 and 4 (each within the scatter of the next); then compounds 2 and 3 (each within the scatter of the next).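

Changing pyrrolidin-1-yl to 2-methylpyrrolidin-1-yl, with nothing else altered, gives a 100-fold lower number from compound 2 to compound 4 (2.01 log units; beyond the scatter) in this assay and shows that this saturated ring carbon responds strongly to one added methyl. With that methyl present, hydrogen in place of (1H-pyrazol-4-yl)amino on an aromatic carbon gives a 2.0-fold higher number from compound 1 to compound 4 (0.30 log units; within the scatter) and so leaves the number within the scatter. No supporting data explain the size of the methyl step.

From the compounds shown here alone, whether ethyl or hydroxymethyl on this carbon would serve as well remains open. So does the size of the methyl step on the core of compound 3.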